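Vero cytotoxicity limits in the series, extended to compound 4

A few compounds are considered here, and "the series" means these few. Any claim that something is new, unique, unknown or untested is made for them only; others in the source may bear on it.

The shared core is drawn for compound 1 as `COC(=O)c1cc(-c2cccc(NC(=O)c3ccc(/C=C/C(=O)c4ccc(C)c(F)c4)cc3)c2)on1`. In an ADME assay on Vero cells (Chlorocebus sabaeus) for cytotoxicity, read by MTT assay, with a stated time of 72 h (a higher number here means that more compound is tolerated, a lower number that less compound is tolerated), compound 1 gives > 50 ug/mL, which is a limit of the assay and not a number. Compound 2 `COC(=O)c1cc(-c2cccc(NC(=O)c3ccc(/C=C/C(=O)c4ccc(C)c([N+](=O)[O-])c4)cc3)c2)on1` carries nitro in place of fluoro on an aromatic carbon. In this assay compound 2 gives > 80 ug/mL, again a limit and not a number. Compound 3 `COC(=O)c1cc(-c2cccc(NC(=O)c3ccc(/C=C/C(=O)c4ccc(CC(C)C)cc4)cc3)c2)on1` carries 4-isobutylphenyl in place of 3-fluoro-4-methylphenyl on a carbonyl carbon. In this assay compound 3 gives > 10 ug/mL, also a limit and not a number. Every step between the three is left unreadable by the two limits: a step that the two limits leave unreadable from compound 1 to compound 2, a step that the two limits leave unreadable from compound 1 to compound 3 and a step that the two limits leave unreadable from compound 2 to compound 3. Compound 3 therefore stands only at a limit, as do its two neighbours, at the limit of > 10 ug/mL in this assay, at which 1 of the 3 values shown sits, the limit of > 50 ug/mL in this assay, at which 1 of the 3 values shown sits, and (the limit of > 80 ug/mL in this assay, at which 1 of the 3 values shown sits). Compound 4 `COC(=O)c1cc(-c2cccc(NC(=O)c3ccc(/C=C/C(=O)c4cccc(Br)c4)cc3)c2)on1` carries 3-bromophenyl in place of 4-isobutylphenyl on a carbonyl carbon. Among the compounds with values here, no measured step yields a size, so no direction beyond the scatter can be expected; the three limits show only tolerance up to each top. Compound 4 is expected to sit at 60 ug/mL, between 20 ug/mL and 150 ug/mL, most likely again reported as a limit. The expected step is a step that the limit leaves unreadable from compound 3 to compound 4.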

Compound 4, half-maximal cytotoxic concentration: > 100 ug/mL
Compound 4 gave a limit, no number; the forecaster's own chance of this, stated with the estimate: 70%; at least 1.6-fold (0.22 log units) between middle value and limit.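

In this assay compound 4 gives > 100 ug/mL, a limit and not a number. Within the data shown here, compound 1, compound 2 and compound 3 also stand only at limits, so no step to compound 4 can be read. The compounds shown leave open where the cytotoxic concentration of each actually lies.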